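Branched to Linear Alkoxy Chain on a Chalcone Core

The source may hold more compounds than are shown below. What is called first, only, known or untested is meant among the compounds shown, and "the series" means these compounds.

Compound 1 `CC(C)=CCOc1cccc(O)c1C(=O)/C=C/c1ccc(O)cc1`: > 30000 nM
Compound 2 `CC(C)(C)CCOc1cccc(O)c1C(=O)/C=C/c1ccc(O)cc1`: 3130 nM
Compound 3 `CC(C)COc1cccc(O)c1C(=O)/C=C/c1ccc(O)cc1`: 3220 nM

In a functional assay on NCI-H23 cells (Homo sapiens) for antiproliferative activity, read by sulforhodamine B assay (on this read-out higher numbers stand for weaker inhibition of growth and lower numbers for stronger inhibition of growth), compound 1 gives only a limit, > 30000 nM, and no number. Compound 2 reaches 3130 nM and compound 3 reaches 3220 nM, so that compound 3 stands highest of the two numbers, with compound 2 nearest and within the scatter of it.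

Compound 4 `CCCCOc1cccc(O)c1C(=O)/C=C/c1ccc(O)cc1` has not been measured. It differs from compound 3 in one place: propyl in place of isopropyl on a saturated chain carbon bound to an oxygen on an aromatic ring.

Within the data shown here, two measured steps bear on this change. The step of a 1.0-fold higher number from compound 2 to compound 3 (0.01 log units; within the scatter) shows that exchanging one saturated branched chain for another leaves the number unchanged. The steps of an at least 9.5-fold lower number from compound 1 to compound 2 (0.98 log units; beyond the scatter) and an at least 9.3-fold lower number from compound 1 to compound 3 (0.96 log units; beyond the scatter) show large movements only where the chain on the oxygen changes from unsaturated to saturated; compound 1 sits at the limit (the limit of > 30000 nM in this assay, at which 1 of the 3 values shown sits), so the true size of those steps is not known. The move from isopropyl to propyl keeps a saturated chain of the same size, and compound 3 is therefore expected to pass to compound 4 with a step of a 1.1-fold lower number from compound 3 to compound 4 (0.03 log units; within the scatter), within the scatter. Compound 4 is estimated at 3000 nM, between 1200 nM and 8000 nM.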

Compound 4, concentration for 50% growth inhibition: > 30000 nM
Compound 4: only a limit was reported; the forecaster's own chance of this, stated with the estimate: 5%; at least 10-fold (1.00 log units) between middle value and limit.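

In this assay compound 4 gives only a limit, and compound 1 sits at that same limit: the limit of > 30000 nM in this assay, at which 2 of the 4 values shown sit.

Exchanging isopropyl for propyl on a saturated chain carbon bound to an oxygen on an aromatic ring keeps the same atoms yet gives an at least 9.3-fold higher number from compound 3 to compound 4 (0.96 log units; beyond the scatter), and the comparison with the neopentyl-bearing chain gives an at least 9.5-fold higher number from compound 2 to compound 4 (0.98 log units; beyond the scatter), so a saturated chain alone does not keep the number low. The earlier compounds shown here showed only that two branched saturated chains lie within the scatter of each other, whereas the unbranched butoxy chain now shows that the shape of the chain matters at this place, though branching alone does not suffice: compound 1, with its branched unsaturated chain, goes against that reading.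

On these data alone, the step between compound 1 and compound 4 cannot be read, as both values are limits, and the true size of the other two new steps stays unknown. As far as these compounds go, it remains open whether a longer chain such as hexyl, or a chain ending in an amine or a carboxylic acid, would behave like the butoxy chain of compound 4 or like the branched chains of compound 2 and compound 3.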